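Removing the 2-benzoylethenyl group from compound 3

The source may report more compounds than this note shows. Statements on the series, on what has been measured and on what is new or still open speak of the compounds shown alone.

Measured in a functional assay on Raji cells (Homo sapiens) for cytotoxicity, with a stated time of 72 h; a lower number here means that less compound is needed, a higher number that more compound is needed for the effect:
Compound 1 `CCOC(=O)/C(C)=C/c1cc(/C=C/[C@](C)(/C=C/c2ccc(OC)cc2)CCC=C(C)C)ccc1O`: > 26000 nM, a limit.
Compound 2 `COc1ccc(/C=C/[C@@](C)(/C=C/c2ccc(O)c(/C=C/C(=O)OCc3ccccc3)c2)CCC=C(C)C)cc1`: > 26000 nM, a limit.
Compound 3 `COc1ccc(/C=C/[C@@](C)(/C=C/c2ccc(O)c(/C=C/C(=O)c3ccccc3)c2)CCC=C(C)C)cc1`: > 26000 nM, a limit.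

Compound 3 has no number, and neither do the other two: the limit of > 26000 nM in this assay, at which 3 of the 3 values shown sit. The next compound is compound 4 `COc1ccc(/C=C/[C@@](C)(/C=C/c2ccc(O)cc2)CCC=C(C)C)cc1`, and the change is hydrogen in place of 2-benzoylethenyl on an aromatic carbon. It places hydrogen on an aromatic carbon, ortho to a hydroxy group.

Going by the values given here, three measured steps bear on this: a step that the two limits leave unreadable from compound 1 to compound 2, a step that the two limits leave unreadable from compound 1 to compound 3 and a step that the two limits leave unreadable from compound 2 to compound 3. None of them gives a size, and none removes the group outright. The expectation in this assay therefore starts from compound 3, whose > 26000 nM is a limit. No step beyond the scatter is expected, and no direction can be read from these data. The estimated step is a number no higher from compound 3 to compound 4 (the limit leaves the size open). A report of a limit alone is the likeliest outcome. For compound 4 the estimate is 26000 nM, with an expected range of 9000 nM to 60000 nM.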

Compound 4, half-maximal effective concentration: > 26000 nM
Compound 4: no number, only a limit; the forecaster's own chance of this, stated with the estimate: 70%; the middle value sits exactly at the limit.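

Compound 4 sits at the same limit as compound 1, compound 2 and compound 3, so no step among these four compounds can be read: the limit of > 26000 nM in this assay, at which 4 of the 4 values shown sit.

The compounds shown leave open whether any of the groups on that aromatic carbon, or hydrogen in their place, shifts the read-out in either direction.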